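Three Hydroxy Groups Replace One on the Ester Ring

The source may report more compounds than this note shows. Statements on the series, on what has been measured and on what is new or still open speak of the compounds shown alone.

Within the data shown here, compound 2 `COc1ccc(C2CC(=NOC(=O)c3ccccc3O)CC(c3ccc(OC)cc3)N2C)cc1` stands at the lower of the two numbers measured so far. In a functional assay, with a stated time of 30 min (on this read-out lower numbers stand for stronger inhibition and higher numbers for weaker inhibition), compound 2 gives 29000 nM, whereas compound 1 `COc1ccc(C2CC(=NOC(=O)c3ccccc3)CC(c3ccc(OC)cc3)N2C)cc1` gives 375000 nM. Among the measured compounds shown here, the only measured step, a 13-fold lower number from compound 1 to compound 2 (1.11 log units; beyond the scatter), is therefore the sole guide to what follows. Compound 3 `COc1ccc(C2CC(=NOC(=O)c3cc(O)c(O)c(O)c3)CC(c3ccc(OC)cc3)N2C)cc1` carries the change (3,4,5-trihydroxyphenyl in place of 2-hydroxyphenyl on a carbonyl carbon), at a carbonyl carbon whose other neighbour is oxygen next to a carbonyl group. The step from compound 1 to compound 2 bears on this change in that it also added a hydroxy group to the same aromatic ring, and it was large. For the measured compounds named here, no measured pair, however, shows what three hydroxy groups in these positions do, so the size of the next step is uncertain. The expected step is a 2.9-fold lower number from compound 2 to compound 3 (0.46 log units; beyond the scatter), a further lowering in this assay that is smaller than the measured one. The estimate for compound 3 in this assay is 10000 nM, with a range from 2000 nM to 60000 nM.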

Compound 3, half-maximal inhibitory concentration: 18000 nM
The estimate for compound 3 lay 1.8-fold (0.26 log units) below the measured number; the range from low to high includes it.
By their numbers in this assay, from the lowest: compounds 3 and 2 (each within the scatter of the next); then compound 1.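

In this assay, replacing 2-hydroxyphenyl with 3,4,5-trihydroxyphenyl on this carbonyl carbon gives a 1.6-fold lower number from compound 2 to compound 3 (0.21 log units; within the scatter), so the read-out does not separate these two rings. Replacing the phenyl of compound 1 with 3,4,5-trihydroxyphenyl gives a 21-fold lower number from compound 1 to compound 3 (1.32 log units; beyond the scatter), which, like a 13-fold lower number from compound 1 to compound 2 (1.11 log units; beyond the scatter), is a large step. At this position, then, both hydroxy-bearing rings stand apart from phenyl, while the change from 1 hydrogen-bond donor on 2-hydroxyphenyl to 3 on 3,4,5-trihydroxyphenyl brings no step beyond the scatter. No independent evidence is available to explain this outcome.

The compounds shown leave open whether the result depends on hydroxy groups as such, since no ring here carries a methoxy group, an amine or a carboxylic acid in their place. They also cannot separate the number of hydroxy groups from where those groups sit, as the two hydroxy-bearing rings differ in both respects.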